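Cytotoxicity Series Held at Assay Limits, Ethoxy Analogue Pending

A few compounds are considered here, and "the series" means these few. Any claim that something is new, unique, unknown or untested is made for them only; others in the source may bear on it.

Three compounds share one core and differ only in the group on a single aromatic carbon. Compound 1 `CC(C)CNc1nc(N)nc2c1ncn2/C=C1/CC1(CO)CO` carries isobutylamino; in an ADME assay on Akata cells (Homo sapiens) for cytotoxicity, with a stated time of 7 days (a lower number here means that less compound is tolerated, a higher number that more compound is tolerated), compound 1 reaches the limit > 24000 nM, which is a limit and not a number. Compound 2 `Nc1nc(OCC(F)(F)F)c2ncn(/C=C3/CC3(CO)CO)c2n1` carries 2,2,2-trifluoroethoxy; in this assay compound 2 sits at the limit > 20000 nM. Compound 3 `Nc1nc(N2CCCC2)c2ncn(/C=C3/CC3(CO)CO)c2n1` carries pyrrolidin-1-yl; in this assay compound 3 stands at the limit > 24000 nM. With every value a limit, the steps a step that the two limits leave unreadable from compound 1 to compound 2, a step that the two limits leave unreadable from compound 1 to compound 3 and a step that the two limits leave unreadable from compound 2 to compound 3 cannot be sized, and no direction can be read from them. Compound 4 `CCOc1nc(N)nc2c1ncn2/C=C1/CC1(CO)CO` differs from compound 3 by ethoxy in place of pyrrolidin-1-yl on an aromatic carbon. Compound 4 is expected to give 30000 nM in this assay, within a range from 10000 nM to 100000 nM. The expected step is a step that the limit leaves unreadable from compound 3 to compound 4.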

Compound 4, half-maximal cytotoxic concentration: > 20000 nM
Compound 4 ended at the assay's limit; the forecaster's own chance of this, stated with the estimate: 80%; the middle value is on the limit's open side.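

In this assay compound 4 stands at > 20000 nM, a limit and not a number, so the steps to it from compound 1, compound 2 and compound 3 cannot be read. The compounds shown leave open where any of the four half-maximal cytotoxic concentrations lies, and whether the group on that aromatic carbon shifts it at all.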